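This account rests on a few compounds, and the source may have more. Where it says the series, first, only, none or still open, it means among the compounds named here.

Four compounds share one core: compound 1 `FC(F)(F)c1cccc(Nc2nc3nonc3nc2Nc2cccc(C(F)(F)F)c2)c1`, compound 2 `Fc1cc(Br)ccc1Nc1nc2nonc2nc1Nc1ccc(Br)cc1F`, compound 3 `Fc1ccccc1Nc1nc2nonc2nc1NCCC(F)(F)F` and the not yet measured compound 4 `Fc1cccc(Nc2nc3nonc3nc2Nc2ccccc2F)c1`. In an assay on mitochondria from L6 cells (Rattus norvegicus) for activation, with a stated time of 90 min (on this read-out lower numbers stand for an effect already at smaller amounts and higher numbers for an effect only at larger amounts of compound), compound 1 gives 700 nM. For compound 2 this assay reports only a limit, < 3000 nM (the limit of < 3000 nM in this assay, at which 1 of the 3 values shown sits). For compound 3 this assay likewise reports only a limit, > 100000 nM (the limit of > 100000 nM in this assay, at which 1 of the 3 values shown sits). So compound 3 stands at the weak end of what is shown, its value being a limit rather than a number, as is one further value. No step between measured compounds differing in one place is shown. The change from compound 3 to compound 4 is 3-fluorophenyl in place of 3,3,3-trifluoropropyl on a nitrogen on an aromatic ring, which gives compound 4 the same arrangement of two substituted amino groups that compound 1 carries. Compound 4 is therefore expected to be active at much smaller amounts, a step of an at least 50-fold lower number from compound 3 to compound 4 (1.69 log units; beyond the scatter) toward stronger activation being expected because compound 1 gives 700 nM. Compound 4 is estimated at 2000 nM, with a range from 300 nM to 20000 nM.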

Compound 4, half-maximal effective concentration: 190 nM
Compound 4: middle estimate off by 11-fold (1.02 log units), on the high side, outside the stated range (below it).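

This is the only comparison among the compounds shown that changes one place, and it shows that the group on this nitrogen matters greatly: in this assay, 3-fluorophenyl in place of 3,3,3-trifluoropropyl gives an at least 520-fold lower number from compound 3 to compound 4 (2.72 log units; beyond the scatter). The earlier compounds shown here offered no such step, so the sensitivity of this position could not be read from them. As far as these compounds go, the full size of the step stays unknown because compound 3 is reported only as a limit: the limit of > 100000 nM in this assay, at which 1 of the 4 values shown sits.

The compounds shown leave open whether the gain comes from the aromatic ring itself or from its fluorine, which a plain phenyl group on this nitrogen would help to separate. They also leave open how a benzyl group or a longer alkyl chain would behave in the same place.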